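The source may hold more compounds than are shown below. What is called first, only, known or untested is meant among the compounds shown, and "the series" means these compounds.

Compound 2 `CCOc1ccc2c(Cl)ccnc2c1` carries an ethoxy group on the shared core, and in a functional assay on BGC-823 cells (Homo sapiens) for cytotoxicity, read by MTT assay, with a stated time of 48 h (on this read-out lower numbers stand for stronger inhibition and higher numbers for weaker inhibition), compound 2 gives 3910 nM. Going by the values given here, its only measured neighbour, compound 1 `CCCCOc1ccc2c(Cl)ccnc2c1`, gives 3610 nM in this assay; the difference, a 1.1-fold higher number from compound 1 to compound 2 (0.03 log units; within the scatter), shortens the alkoxy chain yet leaves the number unchanged within the scatter, so compound 2 stands at one end of the two numbers without being set apart from compound 1. Compound 3 `CC(C)Oc1ccc2c(Cl)ccnc2c1` is not yet measured. It differs from compound 2 by methyl in place of hydrogen on a saturated chain carbon bound to an oxygen on an aromatic ring and a saturated chain carbon. Among the compounds with values here, the one measured step that bears on this change also altered the same alkoxy chain and stayed within the scatter. For compound 3 the step of a 1.0-fold lower number from compound 2 to compound 3 (0.00 log units; within the scatter) is therefore expected to fall within the scatter as well, in no clear direction. Compound 3 is estimated at 3900 nM, with a range from 1900 nM to 8000 nM.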

Compound 3, half-maximal inhibitory concentration: 2630 nM
Compound 3: the middle estimate sits 1.5-fold (0.17 log units) above what was measured; low and high end bracket the measured number.
By their numbers in this assay, from the lowest: compounds 3, 1 and 2 (each within the scatter of the next).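

In this assay, ethoxy to isopropoxy gives a 1.5-fold lower number from compound 2 to compound 3 (0.17 log units; within the scatter), and isopropyl in place of butyl on the oxygen gives a 1.4-fold lower number from compound 1 to compound 3 (0.14 log units; within the scatter). The earlier pair differed only in the length of a straight chain, whereas this methyl on the saturated chain carbon bound to the oxygen makes the chain branched, and the number still stays within the scatter of both straight-chain compounds, so neither change of chain length nor this branching sets any of the three compounds apart. Nothing given here offers an explanation for these numbers.

All three groups on this oxygen are simple saturated chains, so they say little about a different kind of group there. As far as these compounds go, what a benzyl group, a chain ending in an amine or one ending in a carboxylic acid would do to the number remains open.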